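The source may hold more compounds than are shown below. What is called first, only, known or untested is meant among the compounds shown, and "the series" means these compounds.

The measured compounds are:
Compound 1 `Cc1ccc(NC(=S)NC(=O)c2ccc(OCc3cccc(C(F)(F)F)c3)cc2)cc1-c1nc2ccccc2[nH]1`, which gives 8200 nM in a functional assay on HT-29 cells (Homo sapiens) for inhibition, read by MTT assay, with a stated time of 48 h; a higher number here means a weaker inhibitor, a lower number a stronger inhibitor.
Compound 2 `Cc1ccc(NC(=S)NC(=O)c2ccc(OCc3ccccc3F)cc2)cc1-c1nc2ccccc2[nH]1`, which gives 1870 nM in this assay.
Compound 3 `Cc1ccc(COc2ccc(C(=O)NC(=S)Nc3ccc(C)c(-c4nc5ccccc5[nH]4)c3)cc2)cc1`, which gives 14200 nM in this assay.

Compound 3 has the highest number of the three. Compound 1 lies nearest to it, and the step of a 1.7-fold higher number from compound 1 to compound 3 (0.24 log units; within the scatter) stays within the scatter; compound 2 lies furthest from it, as the step of a 7.6-fold higher number from compound 2 to compound 3 (0.88 log units; beyond the scatter) shows. Compound 4 `Cc1ccc(NC(=S)NC(=O)c2ccc(OCc3cccc(F)c3)cc2)cc1-c1nc2ccccc2[nH]1` has not yet been measured. It differs from compound 3 in one place: 3-fluorophenyl in place of 4-methylphenyl on a saturated chain carbon bound to an oxygen on an aromatic ring. For the measured compounds named here, three measured steps bear on this position. The step of a 4.4-fold lower number from compound 1 to compound 2 (0.64 log units; beyond the scatter) and the step of a 7.6-fold higher number from compound 2 to compound 3 (0.88 log units; beyond the scatter) both point the same way, the compound carrying a fluorophenyl giving the lower number, while the step of a 1.7-fold higher number from compound 1 to compound 3 (0.24 log units; within the scatter) is within the scatter. Going by the values given here, no measured pair exchanges 4-methylphenyl for 3-fluorophenyl directly, so the size of the step is uncertain; the value of compound 2 argues for a clear drop, the value of compound 1 for a smaller one. Compound 4 is therefore expected to give a lower number than compound 3 in this assay, a step estimated as a 3.6-fold lower number from compound 3 to compound 4 (0.55 log units; beyond the scatter). The estimate for compound 4 is 4000 nM, with a range from 1500 nM to 11000 nM.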

Compound 4, half-maximal inhibitory concentration: 55300 nM
Compound 4: middle estimate off by 14-fold (1.14 log units), on the low side, outside the stated range (above it).
By their numbers in this assay, from the lowest: compound 2; then compounds 1 and 3 (each within the scatter of the next); then compound 4.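

In this assay, 3-fluorophenyl in place of 2-fluorophenyl gives a 30-fold higher number from compound 2 to compound 4 (1.47 log units; beyond the scatter) and is the largest step in the set, so the presence of a fluorophenyl group does not by itself bring a lower number at this position; where the fluoro sits on the ring matters. For the compounds shown here, the other two steps, a 3.9-fold higher number from compound 3 to compound 4 (0.59 log units; beyond the scatter) and a 6.7-fold higher number from compound 1 to compound 4 (0.83 log units; beyond the scatter), are also beyond the scatter, which makes compound 4 the weakest of the four, with 3-fluorophenyl below both 4-methylphenyl and 3-(trifluoromethyl)phenyl, and leaves compound 2 as the only fluorophenyl compound with a lower number than these two. Nothing among the data given accounts for this difference between the two fluorophenyl groups.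

From the compounds shown here alone, it remains open whether the lower number of compound 2 is specific to fluoro, or would also appear with a 2-chlorophenyl or 2-methoxyphenyl group on the same saturated chain carbon. Going by these compounds, how a 4-fluorophenyl group would compare with the 2-fluorophenyl and 3-fluorophenyl groups, and whether this order holds in cell lines other than the one used here, also stays open.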